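Extending the Ester Chain on the Furan Amine

The source may report more compounds than this note shows. Statements on the series, on what has been measured and on what is new or still open speak of the compounds shown alone.

Measured so far:
compound 1, `Cc1ncc(CO)c2c(Nc3ccccc3)c(NCc3ccccc3)oc12`, gives 1680 nM in a functional assay on HEK293 cells for agonist activity at Toll-like receptor 8 (Homo sapiens), read by reporter gene assay; on this read-out lower numbers stand for an effect already at smaller amounts and higher numbers for an effect only at larger amounts of compound.
compound 2, `CCOC(=O)CNc1oc2c(C)ncc(CO)c2c1Nc1ccccn1`, is reported in this assay as "not active" (no number reported).

Compound 2 therefore stands without a single number; of the two measured compounds only compound 1 shows a numerical effect, and compound 2 does not reach one. Compound 3, `Cc1ncc(CO)c2c(Nc3ccccn3)c(NCCC(=O)OC(C)(C)C)oc12`, carries the change ((tert-butoxycarbonyl)methyl in place of ethoxycarbonyl on a saturated chain carbon bound to a nitrogen on an aromatic ring). Going by the values given here, nothing measured connects the two ester chains, so no computed step is available, and with compound 2 lacking a number the direction of any step cannot be anchored. The expectation is that compound 3 stays weak in this assay, most likely within the scatter of compound 2 or showing at best a modest gain that may still fail to yield a number. The estimate for compound 3 in this assay is 6000 nM, in the range 1500 nM to 30000 nM.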

Compound 3, half-maximal effective concentration: 7640 nM
Estimate against measurement, compound 3: 1.3-fold (0.10 log units) below; the measured number falls inside the stated range.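

In this assay, going by these compounds alone, compound 3 gives 7640 nM and compound 2 has no number, so no step between them can be read. The compounds shown leave open how changing the ester chain alone affects the read-out. No available evidence bears on this result.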